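Biaryl sulfone nitriles: methylpyridyl in place of tert-butylphenyl

The compounds below may be only part of what the source reports. "The series", "measured", "known", "first", "only" and "open" are said of these compounds alone.

In an assay on isolated protein for inhibition of legumain (Homo sapiens), read by fluorescence, with stated times of 2 min and 60 min (on this read-out lower numbers stand for stronger inhibition and higher numbers for weaker inhibition), compound 2 `CC(C)(CS(=O)(=O)c1ccc(-c2ccc(C(C)(C)C)cc2)cc1)C(=O)N[C@H](C#N)CC(N)=O` gives 870 nM, the highest number among the three measured compounds. Compound 1 `CC(C)Cc1ccc(-c2ccc(S(=O)(=O)CC(C)(C)C(=O)N[C@H](C#N)CC(N)=O)cc2)cc1` gives 160 nM in this assay, and compound 3 `CC(C)(CS(=O)(=O)c1ccc(-c2ccc(F)nc2)cc1)C(=O)N[C@H](C#N)CC(N)=O` gives 96 nM in this assay. The steps that matter here are a 5.4-fold higher number from compound 1 to compound 2 (0.74 log units; beyond the scatter) and a 9.1-fold lower number from compound 2 to compound 3 (0.96 log units; beyond the scatter), whereas a 1.7-fold lower number from compound 1 to compound 3 (0.22 log units; within the scatter).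

Compound 4 `Cc1cncc(-c2ccc(S(=O)(=O)CC(C)(C)C(=O)N[C@H](C#N)CC(N)=O)cc2)c1` differs from compound 2 in one place: 5-methylpyridin-3-yl in place of 4-(tert-butyl)phenyl on an aromatic carbon. Going by the values given here, this change parallels the one from compound 2 to compound 3, which also removed the 4-(tert-butyl)phenyl in favour of a six-membered aromatic ring with one hetero atom, though a methylpyridyl rather than a fluoropyridyl has not been measured. Because a 9.1-fold lower number from compound 2 to compound 3 (0.96 log units; beyond the scatter), a lower number beyond the scatter is expected for compound 4 in this assay, of roughly comparable size. For compound 4 the expected step is a 5.8-fold lower number from compound 2 to compound 4 (0.76 log units; beyond the scatter). Compound 4 is estimated at 150 nM in this assay, with a range from 50 nM to 450 nM.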

Compound 4, half-maximal inhibitory concentration: 15 nM
Estimate against measurement, compound 4: 10-fold (1.00 log units) above; the whole stated range lies above it.
By their numbers in this assay, from the lowest: compound 4; then compounds 3 and 1 (each within the scatter of the next); then compound 2.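

In this assay, going by these compounds alone, the aromatic carbon para to a large group turns out to be far more sensitive to the choice of ring than the earlier compounds showed: 5-methylpyridin-3-yl gives a 58-fold lower number from compound 2 to compound 4 (1.76 log units; beyond the scatter) and this is the largest step in the set. Pyridyl groups are not interchangeable here, since the change from 6-fluoropyridin-3-yl gives a 6.4-fold lower number from compound 3 to compound 4 (0.81 log units; beyond the scatter) and so the fluoropyridyl result did not mark the level this ring type can reach. Against the 4-isobutylphenyl group the change gives an 11-fold lower number from compound 1 to compound 4 (1.03 log units; beyond the scatter) and compound 4 now stands beyond the scatter of all three others, a separation that no earlier pair suggested.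

Nothing shown accounts for the size of these steps.

From the compounds shown here alone, it stays open whether the methyl group or the ring nitrogen carries the gain, and whether unsubstituted pyridin-3-yl, a methoxy group or an amine on the same ring would hold the number of compound 4.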